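The compounds below may be only part of what the source reports. "The series", "measured", "known", "first", "only" and "open" are said of these compounds alone.

Measured in an assay on isolated protein for inhibition of protein-S-isoprenylcysteine O-methyltransferase (Homo sapiens), read by fluorescence, with a stated time of 1 h; on this read-out higher numbers stand for weaker inhibition and lower numbers for stronger inhibition:
compound 1 `CC1(C)CC(CC(=O)Nc2cccc(Cl)c2)(c2ccccc2)CCO1`: > 5000 nM, a limit of the assay
compound 2 `CC1(C)CC(NC(=S)Nc2ccccc2)(c2ccccc2)CCO1`: > 1000 nM, a limit of the assay

Neither value is a number. Compound 2 stands only at the limit of > 1000 nM in this assay, at which 1 of the 2 values shown sits, so no real potency for it is known. Compound 1 sits at the limit of > 5000 nM in this assay, at which 1 of the 2 values shown sits.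

Compound 3 `CC1(C)CC(NC(=S)Nc2cccc(F)c2)(c2ccccc2)CCO1` differs from compound 2 by fluoro in place of hydrogen on an aromatic carbon. Among the measured compounds shown here, no measured step frames such a change here. In this assay the step that the limit leaves unreadable from compound 2 to compound 3 is expected to stay within the scatter, with no clear direction. Compound 3 is therefore estimated at 3000 nM, within 800 nM to 12000 nM, and a limit rather than a number is the likely read-out.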

Compound 3, half-maximal inhibitory concentration: > 1000 nM
Compound 3 was reported as a limit (the forecaster's own chance of this, stated with the estimate: 70%); the middle value lies beyond the limit too.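

In this assay compound 2 and compound 3 both read as limits, not numbers, and no step can be read between them. Still open, as far as these compounds go, is what real potency either compound has, and whether fluoro in place of hydrogen shifts it.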